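Removing the aromatic chloro: compound 3 to compound 4

This account rests on a few compounds, and the source may have more. Where it says the series, first, only, none or still open, it means among the compounds named here.

Measured compounds:
- Compound 1, `O=C(CC(CC(=O)NC1Cc2ccccc2C1)c1ccc(Cl)cc1)NCCN1CCCCC1`, gives 35500 nM in a functional assay on MCF7 cells (Homo sapiens) for inhibition; a higher number here means a weaker inhibitor, a lower number a stronger inhibitor.
- Compound 2, `O=C(CC(CC(=O)NC1Cc2ccccc2C1)c1ccccc1)NCCN1CCCCC1`, reaches only a limit in this assay, > 100000 nM.
- Compound 3, `CCNCCNC(=O)CC(CC(=O)N(CC)C1Cc2ccccc2C1)c1ccc(Cl)cc1`, gives 14400 nM in this assay.

The change from compound 1 to compound 2 is hydrogen in place of chloro on an aromatic carbon; the step is an at least 2.8-fold higher number from compound 1 to compound 2 (0.44 log units; beyond the scatter). The value of compound 2 is a limit, (the limit of > 100000 nM in this assay, at which 1 of the 3 values shown sits).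

The difference between the core of compound 1 and the core of compound 3 is not broken down here.

Compound 4, `CCNCCNC(=O)CC(CC(=O)N(CC)C1Cc2ccccc2C1)c1ccccc1`, is not yet measured. It differs from compound 3 by hydrogen in place of chloro on an aromatic carbon, the same change as from compound 1 to compound 2, at the same kind of place.

The step in this assay from compound 3 to compound 4 is expected to be a 4.2-fold higher number from compound 3 to compound 4 (0.62 log units; beyond the scatter), resting on the measured step of an at least 2.8-fold higher number from compound 1 to compound 2 (0.44 log units; beyond the scatter), whose size is known only as a lower bound. For compound 4 the estimate in this assay is 60000 nM, spanning 25000 nM to 150000 nM.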

Compound 4, half-maximal inhibitory concentration: > 100000 nM
Compound 4 ended at the assay's limit; the forecaster's own chance of this, stated with the estimate: 30%; middle value at least 1.6-fold (0.22 log units) away from the limit.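

In this assay, going from 4-chlorophenyl to phenyl gives an at least 6.9-fold higher number from compound 3 to compound 4 (0.84 log units; beyond the scatter) as a further weakening on this second core. Compound 4 gives > 100000 nM in this assay, and this value is a limit of the assay, not a number. The direction of the change therefore holds on both cores shown, but its size cannot be compared between them: the same change on two cores in this assay, an at least 2.8-fold higher number (0.44 log units; beyond the scatter) from compound 1 to compound 2 and an at least 6.9-fold higher number (0.84 log units; beyond the scatter) from compound 3 to compound 4; the limit leaves it open whether they differ

Still open, going by these compounds, is whether a bromo, methoxy or trifluoromethyl group on that aromatic carbon would match or outdo the chloro in this assay. The two phenyl compounds, compound 2 and compound 4, also cannot be ranked against each other: the limit of > 100000 nM in this assay, at which 2 of the 4 values shown sit.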